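This account rests on a few compounds, and the source may have more. Where it says the series, first, only, none or still open, it means among the compounds named here.

Measured so far in an ADME assay on HepG2 cells (Homo sapiens) for cytotoxicity, with a stated time of 72 h; on this read-out higher numbers stand for an effect only at larger amounts of compound and lower numbers for an effect already at smaller amounts:
compound 1 `Cc1cc(NC(=O)Nc2cccc(C(N)=O)c2)c2ccccc2n1` – > 25000 nM
compound 2 `Cc1cc(NC(=O)Nc2ccccc2C(C)(C)C)c2ccccc2n1` – > 25000 nM

Compound 1 gives only a limit in this assay, > 25000 nM, and no number. Compound 2 likewise gives only a limit, > 25000 nM. Both measured compounds thus sit at the same point, (the limit of > 25000 nM in this assay, at which 2 of the 2 values shown sit), so compound 1 is not placed above or below compound 2 on the numbers shown; no ordering can be read from them.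

Compound 3 `Cc1cc(NC(=O)Nc2cccc(N(C)C)c2)c2ccccc2n1` is not yet measured. It differs from compound 1 in one place, (dimethylamino in place of carbamoyl on an aromatic carbon), on the shared core of compound 1.

Within the data shown here, for this change, no step between measured compounds is at hand to draw on. Since compound 1 reaches only the limit > 25000 nM, no step beyond the scatter is expected from compound 1 to compound 3: the estimated step is a step that the limit leaves unreadable from compound 1 to compound 3. Compound 3 is expected at 30000 nM, within 15000 nM to 80000 nM, most likely again reported as a limit.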

Compound 3, half-maximal effective concentration: > 25000 nM
Compound 3: only a limit was reported (the forecaster's own chance of this, stated with the estimate: 80%); the middle value lies beyond the limit too.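

In this assay compound 3 gives only a limit, > 25000 nM. Compound 1 also gives only a limit, so no step from compound 1 to compound 3 can be read: the limit of > 25000 nM in this assay, at which 3 of the 3 values shown sit.

The compounds shown leave open whether dimethylamino in place of carbamoyl changes the read-out in this assay at all.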